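Swapping the aryl group on the amide nitrogen of a quinazoline series

This account rests on a few compounds, and the source may have more. Where it says the series, first, only, none or still open, it means among the compounds named here.

Measured so far:
- compound 1 `O=C(CSc1nc(Nc2ccccc2)c2ccccc2n1)Nc1ccccc1Br`: 18600 nM
- compound 2 `O=C(CSc1nc(Nc2ccccc2)c2ccccc2n1)Nc1cccc([N+](=O)[O-])c1`: 28100 nM

Both compounds share one core and differ only in the aryl group on the amide-type nitrogen. In a functional assay on MGC-803 cells (Homo sapiens) for inhibition, read by MTT assay, with a stated time of 72 h (a higher number here means a weaker inhibitor, a lower number a stronger inhibitor), compound 1 gives 18600 nM and compound 2 gives 28100 nM. Within the data shown here, the one measured step, a 1.5-fold higher number from compound 1 to compound 2 (0.18 log units; within the scatter), lies within the scatter, so compound 2 cannot be set apart from compound 1 on these numbers; its value is simply the higher of the two.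

Compound 3 `O=C(CSc1nc(Nc2ccccc2)c2ccccc2n1)Nc1ccc(Cl)cc1` is not yet measured. It differs from compound 2 by 4-chlorophenyl in place of 3-nitrophenyl on an amide-type nitrogen. Among the measured compounds shown here, the only step that bears on this is the one from compound 1 to compound 2, which stayed within the scatter when a differently substituted phenyl was exchanged at the same place. On that basis the estimate for compound 3 is a step of a 1.3-fold lower number from compound 2 to compound 3 (0.13 log units; within the scatter), that is, no change beyond the scatter. The expected value for compound 3 in this assay is 21000 nM, with a range from 8000 nM to 55000 nM.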

Compound 3, half-maximal inhibitory concentration: 40400 nM
The estimate for compound 3 lay 1.9-fold (0.28 log units) below the measured number; the measured number falls inside the stated range.
By their numbers in this assay, from the lowest: compounds 1, 2 and 3 (each within the scatter of the next, the first and the last beyond it).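

In this assay, exchanging 3-nitrophenyl for 4-chlorophenyl on the amide-type nitrogen gives a 1.4-fold higher number from compound 2 to compound 3 (0.16 log units; within the scatter), so these two groups cannot be told apart. Among these compounds, exchanging 2-bromophenyl for 4-chlorophenyl at the same place gives a 2.2-fold higher number from compound 1 to compound 3 (0.34 log units; beyond the scatter), the first step here to go beyond the scatter, though only modestly, which shows that the aryl group on this nitrogen can shift the number, while compound 2 stays within the scatter of both compound 1 and compound 3. Nothing available explains this difference between compound 1 and compound 3.

The compounds shown leave open whether the identity of the halogen or its place on the phenyl ring matters, as 2-bromophenyl and 4-chlorophenyl differ in both. They also leave open how a phenyl carrying an amine or a carboxylic acid, or a longer alkyl chain in place of the phenyl, would behave on this nitrogen in this assay.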